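The compounds below may be only part of what the source reports. "The series", "measured", "known", "first", "only" and "open" are said of these compounds alone.

In an ADME assay on Vero cells (Chlorocebus sabaeus) for cytotoxicity, read by MTT assay, with a stated time of 72 h (a lower number here means that less compound is tolerated, a higher number that more compound is tolerated), compound 1 `COC(=O)CCN1CCN(c2c(F)cc3c(=O)c(C(=O)O)cn(C4CC4)c3c2OC)CC1C` reads > 1000 ug/mL and this is a limit of the assay, not a number. Among the compounds with values here, compound 2 `COc1c(N2CCN(C/C(C)=N/NC(=O)c3ccncc3)C(C)C2)c(F)cc2c(=O)c(C(=O)O)cn(C3CC3)c12` gives 250 ug/mL as the only actual number so far. Compound 3 `CO/N=C(\C)CCN1CCN(c2c(F)cc3c(=O)c(C(=O)O)cn(C4CC4)c3c2OC)CC1C` is not yet measured, and the change leading to it is a group of 6 heavy atoms (4 carbon, 1 nitrogen, 1 oxygen; no ring) in place of a group of 12 heavy atoms (8 carbon, 3 nitrogen, 1 oxygen; one six-membered aromatic ring with 1 hetero atom), on a saturated chain carbon bound to an amine nitrogen in a ring at the same place, on a saturated chain carbon bound to an amine nitrogen in a ring. Within the data shown here, one measured step bears on this: an at least 4.0-fold lower number from compound 1 to compound 2 (0.60 log units; beyond the scatter) and it lies beyond the scatter. Its size is only a minimum, as one end of it is a limit. The group of 6 heavy atoms in compound 3 has no ring, like the group of 5 heavy atoms in compound 1, but the two groups are not the same. Among the measured compounds shown here, with an at least 4.0-fold lower number from compound 1 to compound 2 (0.60 log units; beyond the scatter) as the single guide, a partial reversal toward a higher number is expected in this assay for compound 3. The estimated size is a 2.4-fold higher number from compound 2 to compound 3 (0.38 log units; beyond the scatter) on this reading, and a reading that reaches the limit remains possible. For compound 3 the estimate is 600 ug/mL with an expected range of 250 ug/mL to 1200 ug/mL in this series.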

Compound 3, half-maximal cytotoxic concentration: 157 ug/mL
For compound 3 the middle estimate is 3.8-fold (0.58 log units) above the measured one, and the stated range ends above it.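

In this assay, a ring-free group of 6 heavy atoms in place of the group holding the six-membered aromatic ring, on a saturated chain carbon bound to an amine nitrogen in a ring, gives a 1.6-fold lower number from compound 2 to compound 3 (0.20 log units; within the scatter), so compound 2 and compound 3 cannot be told apart here and the aromatic ring is not needed for a reading in this range. The smaller change is an at least 6.3-fold lower number from compound 1 to compound 3 (0.80 log units; beyond the scatter), with one ring-free group in place of another on a saturated chain carbon, two bonds along the chain from an amine nitrogen in a ring, which shows that having no ring in the side group does not by itself keep the reading at the level of compound 1. Compound 1 stands at a limit, so the step from it gives only a minimum size: the limit of > 1000 ug/mL in this assay, at which 1 of the 3 values shown sits.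

Still open, going by these compounds, is whether the ester of compound 1 is specifically what separates it from compound 2 and compound 3, as these three compounds offer only one ester. Also open, on these data alone, is how a carboxylic acid or a primary amine at the end of this chain, or a longer chain, would read in this assay.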